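Second Phenyl on the Benzyl Ether of Compound 2

The source may hold more compounds than are shown below. What is called first, only, known or untested is meant among the compounds shown, and "the series" means these compounds.

Measured in an assay on CHO cells with metabotropic glutamate receptor 2 (Rattus norvegicus) as the target; on this read-out higher numbers stand for weaker inhibition and lower numbers for stronger inhibition:
- compound 1, `CO[C@@H]1C[C@@H]2[C@H]([C@]1(N)C(=O)O)[C@@]2(F)C(=O)O`, gives 229 nM
- compound 2, `N[C@]1(C(=O)O)[C@H]2[C@@H](C[C@H]1OCc1ccccc1)[C@]2(F)C(=O)O`, gives 131 nM
- compound 3, `N[C@]1(C(=O)O)[C@H]2[C@@H](C[C@H]1OCc1ccc(F)c(F)c1)[C@]2(F)C(=O)O`, gives 40.8 nM

Compound 2 stands between the other two in this assay: there is a 1.7-fold lower number from compound 1 to compound 2 (0.24 log units; within the scatter), and there is a 3.2-fold lower number from compound 2 to compound 3 (0.51 log units; beyond the scatter). Compound 4, `N[C@]1(C(=O)O)[C@H]2[C@@H](C[C@H]1OC(c1ccccc1)c1ccccc1)[C@]2(F)C(=O)O`, differs from compound 2 by phenyl in place of hydrogen on a saturated chain carbon bound to an aromatic carbon and an oxygen on a saturated carbon. Among the compounds with values here, no measured step adds a second phenyl at this place; the nearest guides are the aryl additions at the ether oxygen, a 1.7-fold lower number from compound 1 to compound 2 (0.24 log units; within the scatter) and a 5.6-fold lower number from compound 1 to compound 3 (0.75 log units; beyond the scatter), which show that growth here is tolerated and at most modestly helpful. Compound 4 is therefore expected to give roughly 90 nM in this assay, with a range from 25 nM to 330 nM. This estimate means an expected 1.5-fold lower number from compound 2 to compound 4 (0.16 log units; within the scatter), a change that may not exceed the scatter.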

Compound 4, half-maximal inhibitory concentration: 24.4 nM
Compound 4: the middle estimate sits 3.7-fold (0.57 log units) above what was measured, and the stated range ends above it.
By their numbers in this assay, from the lowest: compounds 4 and 3 (each within the scatter of the next); then compounds 2 and 1 (each within the scatter of the next).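

In this assay there is a 5.4-fold lower number from compound 2 to compound 4 (0.73 log units; beyond the scatter) on adding a second phenyl to the saturated chain carbon bound to an aromatic carbon and an oxygen on a saturated carbon, so this carbon can carry a further ring with a clear gain. The first phenyl, with a 1.7-fold lower number from compound 1 to compound 2 (0.24 log units; within the scatter) as its step, did not clear the scatter, so at this place it is the second ring that clearly moves the number.

On these data alone, whether an amine or a carboxylic acid in place of that second phenyl would also lower the number stays open. Nothing shown gives a reason for this step.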